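Aryl substituent swap on the shared core: bromo analogue

The source may report more compounds than this note shows. Statements on the series, on what has been measured and on what is new or still open speak of the compounds shown alone.

Going by the values given here, compound 3 `COC(=O)c1ccc(N2C(=O)C=CC2OCC(F)(F)F)cc1` gives 12100 nM in a functional assay on MDA-MB-231 cells (Homo sapiens) for inhibition (on this read-out lower numbers stand for stronger inhibition and higher numbers for weaker inhibition), and stands second highest of the three numbers measured so far. Compound 1 `O=C1C=CC(OCC(F)(F)F)N1c1ccc(C(F)(F)F)cc1` gives 2300 nM in this assay, and compound 2 `Cc1ccc(N2C(=O)C=CC2OCC(F)(F)F)cc1` gives 15800 nM. The nearest neighbour of compound 3 is reached by the step of a 1.3-fold lower number from compound 2 to compound 3 (0.12 log units; within the scatter), the furthest by the step of a 5.3-fold higher number from compound 1 to compound 3 (0.72 log units; beyond the scatter).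

Compound 4 `O=C1C=CC(OCC(F)(F)F)N1c1ccc(Br)cc1` differs from compound 3 by bromo in place of methoxycarbonyl on an aromatic carbon.

Among the compounds with values here, no measured step puts bromo at this aromatic carbon, so the steps that bear on the change are the earlier exchanges at the same position. The step of a 6.9-fold higher number from compound 1 to compound 2 (0.84 log units; beyond the scatter) and the step of a 5.3-fold higher number from compound 1 to compound 3 (0.72 log units; beyond the scatter) were both modest and beyond the scatter, while the step of a 1.3-fold lower number from compound 2 to compound 3 (0.12 log units; within the scatter) lay within it. Two of the three groups tried at this carbon give numbers close to each other; only trifluoromethyl gives a clearly lower number. Bromo is not one of those groups, so no direction is fixed by the data. The step to compound 4 in this assay is therefore expected to be small to modest, leaning toward a lower number, and is estimated as a 2.0-fold lower number from compound 3 to compound 4 (0.30 log units; within the scatter).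

Compound 4 is estimated at 6000 nM in this assay, with a range from 2000 nM to 18000 nM.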

Compound 4, half-maximal inhibitory concentration: 7570 nM
Estimate against measurement, compound 4: 1.3-fold (0.10 log units) below, and the stated range covers the measured number.
By their numbers in this assay, from the lowest: compound 1; then compounds 4, 3 and 2 (each within the scatter of the next, the first and the last beyond it).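

In this assay, replacing methoxycarbonyl with bromo at this aromatic carbon, para to a large group, gives a step within the scatter (a 1.6-fold lower number from compound 3 to compound 4 (0.20 log units; within the scatter)), so removing a group with hydrogen-bond acceptors for a single bromine atom leaves no clear mark on the read-out. Bromo does separate from two other groups, though both steps are modest: methyl lies beyond the scatter on one side (a 2.1-fold lower number from compound 2 to compound 4 (0.32 log units; beyond the scatter)), and trifluoromethyl remains clearly apart on the other (a 3.3-fold higher number from compound 1 to compound 4 (0.52 log units; beyond the scatter)), leaving compound 1 with the lowest number of the four. No measured property of these groups is available to account for this order.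

Whether the lower number of compound 1 is specific to trifluoromethyl remains open, as the compounds shown do not include a nitrile, a carboxylic acid, an amine or a chloro group at this carbon. Going by these compounds, all four compounds also share the rest of the core, so it is unknown whether these steps would hold if a longer chain replaced the group carried on that core.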